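From compound 3 to compound 4: losing the chloro

The compounds below may be only part of what the source reports. "The series", "measured", "known", "first", "only" and "open" are said of these compounds alone.

- Compound 1 `COc1c(Br)cccc1C(=O)Nc1ccccc1`: > 100000 nM
- Compound 2 `O=C(Nc1ccccc1)c1cc(Br)cc(Br)c1O`: 34000 nM
- Compound 3 `O=C(Nc1cccc(Cl)c1)c1cccc(Br)c1O`: 32000 nM

In an ADME assay on HEK293 cells (Homo sapiens) for cytotoxicity, read by reporter gene assay and resazurin assay, with a stated time of 48 h (a lower number here means that less compound is tolerated, a higher number that more compound is tolerated), compound 1 gives only a limit of the assay, > 100000 nM. Compound 3, at 32000 nM, stands level with compound 2, at 34000 nM, the two lying within the usual scatter of each other.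

Compound 4 `O=C(Nc1ccccc1)c1cccc(Br)c1O` has yet to be measured. It differs from compound 3 by hydrogen in place of chloro on an aromatic carbon. Going by the values given here, no measured pair isolates this change. Compound 2, which also has no chloro, gives 34000 nM, so no step beyond the scatter is expected in this assay, and any drift should be towards more compound tolerated. The expected step is a 1.5-fold higher number from compound 3 to compound 4 (0.18 log units; within the scatter). For compound 4 the estimated value is 48000 nM, with an expected range of 25000 nM to 100000 nM.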

Compound 4, half-maximal cytotoxic concentration: 82000 nM
Estimate against measurement, compound 4: 1.7-fold (0.23 log units) below; low and high end bracket the measured number.
By their numbers in this assay, from the lowest: compounds 3 and 2 (each within the scatter of the next); then compound 4. At a limit, above all of these: compound 1.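

Going by these compounds alone, compound 4 is the first case where a single change on the shared core gives a modest step in this assay: hydrogen in place of chloro on an aromatic carbon gives a 2.6-fold higher number from compound 3 to compound 4 (0.41 log units; beyond the scatter). Hydrogen in place of bromo on an aromatic carbon runs the same way, with a 2.4-fold higher number from compound 2 to compound 4 (0.38 log units; beyond the scatter), so in both pairs losing a halogen goes with more compound tolerated. Hydrogen in place of methyl on an oxygen on an aromatic ring gives an at least 1.2-fold lower number from compound 1 to compound 4 (0.08 log units; that floor lies within the scatter). The size of this step cannot be read, since it rests on a limit: the limit of > 100000 nM in this assay, at which 1 of the 4 values shown sits.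

On these data alone, whether a fluoro, an amine or a methyl at the chloro's place would be tolerated like hydrogen or like chloro remains open.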